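A few compounds are considered here, and "the series" means these few. Any claim that something is new, unique, unknown or untested is made for them only; others in the source may bear on it.

Compound 1 `CSc1ccc(C)cc1NCC1=NCCN1` is the anchor of this small series. In an assay for binding affinity to Alpha-1A adrenergic receptor (Homo sapiens), read by radioligand binding (a higher number here means a weaker inhibitor, a lower number a stronger inhibitor), compound 1 gives 20.9 nM, the lowest of the three numbers recorded. Its nearest neighbour in the numbers is compound 2 `Cc1ccc(S(C)(=O)=O)c(NCC2=NCCN2)c1`, which in this assay gives 776 nM; the change between these two is a 37-fold higher number from compound 1 to compound 2 (1.57 log units; beyond the scatter). Furthest away stands compound 3 `CC(C)S(=O)(=O)c1ccccc1NCC1=NCCN1`, which in this assay gives 2690 nM; compound 3 differs from compound 1 in more than one place, so the two values can only be set side by side.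

The compound under consideration is compound 4 `CSc1ccc(Cl)cc1NCC1=NCCN1`. Its difference from compound 1 is chloro in place of methyl on an aromatic carbon. Among the measured compounds shown here, none of the measured steps touches this position or this pair of groups: the one step recorded concerns the sulfur-bearing group, and compound 3 is not a single-change neighbour. The data therefore give no direct guide to the size or direction of the change, and the working assumption is an outcome close to compound 1, with a step from compound 1 to compound 4 expected to be a 1.1-fold higher number from compound 1 to compound 4 (0.02 log units; within the scatter), that is, not clearly beyond the scatter. Compound 4 is accordingly estimated in this assay at 22 nM, with a range from 7 nM to 70 nM.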

Compound 4, inhibition constant: 18.6 nM
For compound 4 the middle estimate is 1.2-fold (0.07 log units) above the measured one, and the stated range covers the measured number.
By their numbers in this assay, from the lowest: compounds 4 and 1 (each within the scatter of the next); then compound 2; then compound 3.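

In this assay, chloro in place of methyl on the aromatic carbon para to a methylsulfanyl group gives a 1.1-fold lower number from compound 1 to compound 4 (0.05 log units; within the scatter) and so leaves compound 4 and compound 1 indistinguishable in this assay. Among the compounds shown here, this is the first reading at this position, since the only earlier single-change step, a 37-fold higher number from compound 1 to compound 2 (1.57 log units; beyond the scatter), concerned the sulfur-bearing group and lay beyond the scatter, whereas the step at this position lies within it. The compounds shown offer no measurement that could explain why the two groups read alike here.

As far as these compounds go, one exchange at this position cannot show how far it tolerates other groups, so it remains open whether a methoxy group, an amine or a carboxylic acid on this aromatic carbon would also stay within the scatter of compound 1. From the compounds shown here alone, it is also open whether chloro in place of methyl would read the same way alongside the methylsulfonyl group of compound 2, whose value stands well apart from that of compound 1.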